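Aryl ether series: working notes toward compound 4

A few compounds are considered here, and "the series" means these few. Any claim that something is new, unique, unknown or untested is made for them only; others in the source may bear on it.

Measured so far, each in a functional assay on HEK293 cells for positive allosteric modulation of metabotropic glutamate receptor 5 (Homo sapiens), read by calcium flux; on this read-out higher numbers stand for larger maximal responses and lower numbers for smaller maximal responses:
compound 1, `O=C1c2cc(COc3ccccc3)nn2CCN1c1ccccn1`, gives 69%
compound 2, `COc1ccc(N2CCn3nc(COc4ccccc4)cc3C2=O)nc1`, gives 74%
compound 3, `O=C1c2cc(COc3ccccc3F)nn2CCN1c1ccc(F)cc1`, gives 66%

All three numbers sit within the usual scatter of one another; compound 3 stands beside compound 1 and compound 2 without a separation that the assay can resolve. Among the compounds with values here, the only single-point step measured is a number 5 percentage points higher from compound 1 to compound 2 (within the scatter), on a different ring from the one changed here. Compound 4, `Cc1ccc(OCc2cc3n(n2)CCN(c2ccc(F)cc2)C3=O)cc1`, differs from compound 3 by 4-methylphenyl in place of 2-fluorophenyl on an oxygen on a saturated carbon. Within the data shown here, no measured step touches this phenoxy ring, so the expectation rests on the flat picture so far: a step of a number 1 percentage points higher from compound 3 to compound 4 (within the scatter) is expected, none beyond the scatter. Compound 4 is therefore estimated at 67%, between 53% and 81%.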

Compound 4, largest response reached (Emax), in percent of the reference or control that the assay uses: 58%
For compound 4 the middle estimate is 9 percentage points above the measured one; measured number inside the range.
By their numbers in this assay, from the lowest: compounds 4, 3, 1 and 2 (each within the scatter of the next, the first and the last beyond it).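

In this assay, within the data shown here, the only measured step on this phenoxy ring, 2-fluorophenoxy to 4-methylphenoxy, reads a number 8 percentage points lower from compound 3 to compound 4 (within the scatter) and is the first reading at this position. On the core of compound 3, the exchange therefore gives no separation that the read-out can resolve. No measurement shown bears on the reason for this step.

Open, as far as these compounds go, is whether an amine or a carboxylic acid on this phenoxy ring would separate from compound 3 beyond the scatter. Also open, from the compounds shown here alone, is whether the same exchange reads alike on the core of compound 1.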